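Removing a propyl group from an inactive fused core

This account rests on a few compounds, and the source may have more. Where it says the series, first, only, none or still open, it means among the compounds named here.

Of the compounds shown here, three have been tested in a functional assay for inhibition, with Homo sapiens as the target; a higher number here means a weaker inhibitor, a lower number a stronger inhibitor. Compound 1 `CCCc1ncc2cnnc(S)n12` reaches only the limit of the measurement, reported as > 48000 nM. Compound 2 `Cc1nc(C)n2c(S)nncc12` likewise stops at the limit, given as > 48000 nM. Compound 3 `CCCc1nnc(S)n2c(CCC)nc(C)c12` also gives a limit in this assay, namely > 48000 nM. For the measured compounds named here, none of the three has a real number attached; all sit at the limit of > 48000 nM in this assay, at which 3 of the 3 values shown sit, so no compound can be ranked against another and no step between measured compounds can be given.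

Compound 4 `CCCc1nc(C)c2cnnc(S)n12` has not yet been measured in this assay. It differs from compound 3 in one place: hydrogen in place of propyl on an aromatic carbon. The change removes a small chain from the core that the compounds share, leaving a structure closer in size to compound 1 and compound 2.

Since every measured compound sits at the limit, there is no trend to extend. Because all three values stand at the limit of > 48000 nM in this assay, at which 3 of the 3 values shown sit, the expectation is that the step from compound 3 to compound 4 in this assay, estimated as a step that the limit leaves unreadable from compound 3 to compound 4, is none beyond the scatter. Compound 4 is therefore expected to land at about 60000 nM, in a range from 20000 nM to 200000 nM, most likely reported again only as a limit.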

Compound 4, half-maximal inhibitory concentration: 10000 nM
Compound 4: the middle estimate sits 6.0-fold (0.78 log units) above what was measured, and the stated range ends above it.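

In this assay, the aromatic carbon para to a sulfanyl group turns out to matter: with hydrogen there instead of propyl, the result is an at least 4.8-fold lower number from compound 3 to compound 4 (0.68 log units; beyond the scatter), so compound 3 goes against any idea that a larger compound in this set does better. Compound 4 also separates from the two smaller compounds, with ethyl in place of hydrogen on a saturated chain carbon bound to an aromatic carbon giving an at least 4.8-fold lower number from compound 2 to compound 4 (0.68 log units; beyond the scatter), and methyl in place of hydrogen on an aromatic carbon giving an at least 4.8-fold lower number from compound 1 to compound 4 (0.68 log units; beyond the scatter). Each of these steps starts from a compound that gives only a limit, and together they show that, within these four compounds, a measurable value appears only with the propyl chain and the methyl group present and hydrogen on the aromatic carbon para to the sulfanyl group.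

From the compounds shown here alone, it remains open whether an amine or a chlorine on that aromatic carbon would keep the value of compound 4, or whether only hydrogen does. Going by these compounds, it is equally open whether a butyl chain in place of the remaining propyl would lower the number further, and these compounds give no reason for any of the steps.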